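This account rests on a few compounds, and the source may have more. Where it says the series, first, only, none or still open, it means among the compounds named here.

Compound 1 `CCn1nc(-c2cccnc2)c2ccccc2c1=O` is the reference point of this small series. In an assay on isolated protein (Oryctolagus cuniculus) with Thromboxane-A synthase (Homo sapiens) as the target, tested at 1 uM (a lower number here means less inhibition, a higher number more inhibition at the concentration tested (going by the name of the read-out)), compound 1 gives 87%. Within the data shown here, compound 2 `CCOC(=O)Cn1nc(-c2cccnc2)c2ccccc2c1=O` carries an ethoxycarbonyl in place of the methyl on the saturated chain carbon bound to the aromatic nitrogen, and in this assay compound 2 gives 28%, the lowest of the two numbers measured so far. Among the measured compounds shown here, the single measured step runs a number 59 percentage points lower from compound 1 to compound 2 (beyond the scatter), a change well beyond the scatter of the measurement.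

Compound 3 `O=C(O)CCCn1nc(-c2cccnc2)c2ccccc2c1=O` has not yet been measured. It differs from compound 2 in one place: 2-carboxyethyl in place of ethoxycarbonyl on a saturated chain carbon bound to an aromatic nitrogen. For the measured compounds named here, the only measured step that bears on this change is the one from compound 1 to compound 2, since it concerns the same saturated chain carbon bound to the aromatic nitrogen, and it was large. That step shows that what sits on this chain carbon moves the read-out strongly, but it does not show the direction for a 2-carboxyethyl. Compound 3 is therefore estimated to give 55%, within a wide range from 20% to 85%. This estimate means an expected step of a number 27 percentage points higher from compound 2 to compound 3 (beyond the scatter), upward, though with little confidence.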

Compound 3, a percentage reported as inhibition, at one concentration (the size of the read-out at that concentration, not a potency): 73%
Estimate against measurement, compound 3: 18 percentage points below, and the stated range covers the measured number.
By their numbers in this assay, from the lowest: compound 2; then compound 3; then compound 1.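

In this assay, the exchange of (ethoxycarbonyl)methyl for 3-carboxypropyl on the shared core gives a number 45 percentage points higher from compound 2 to compound 3 (beyond the scatter). Both groups have 5 heavy atoms of the same kinds, so this position responds strongly to how those atoms are joined, not merely to their number or kind, which the first step alone could not show. The series also now shows that a larger substituent here need not cost much: the carboxymethyl in place of hydrogen on the saturated chain carbon gives a number 14 percentage points lower from compound 1 to compound 3 (beyond the scatter), a modest drop, and compound 1 remains the highest of the three. No measurement in hand accounts for either step, and the reason for the recovery remains unexplained.

The compounds shown leave open whether the recovery belongs to the free carboxylic acid or to the longer chain, as the two change together between compound 2 and compound 3. The ethyl ester of the 3-carboxypropyl group, a carboxymethyl group on the aromatic nitrogen and a 3-aminopropyl group would each bear on that question, and none of these stands among the compounds here.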